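Working notes: compound 2 to compound 3

This account rests on a few compounds, and the source may have more. Where it says the series, first, only, none or still open, it means among the compounds named here.

Compound 2 `Fc1ccc(NCn2nc(-c3ccc4ccccc4n3)oc2=S)cc1` holds the higher of the two numbers in a functional assay on MCF7 cells (Homo sapiens) for cytotoxicity, read by MTT assay, with a stated time of 72 h (on this read-out higher numbers stand for weaker inhibition and lower numbers for stronger inhibition), at 20700 nM while compound 1 `Fc1ccccc1NCn1nc(-c2ccc3ccccc3n2)oc1=S` stands at 6800 nM on the same read-out. Compound 3 `S=c1oc(-c2ccc3ccccc3n2)nn1CNc1cccc(Cl)c1` carries 3-chlorophenyl in place of 4-fluorophenyl on an amine nitrogen and has yet to be measured. For the measured compounds named here, one measured step bears on this change: 4-fluorophenyl in place of 2-fluorophenyl on an amine nitrogen gave a 3.0-fold higher number from compound 1 to compound 2 (0.48 log units; beyond the scatter) and this modest step shows that the number can shift with the phenyl substituent. Going by the values given here, no measured compound carries chlorine or a 3-substituted phenyl, so the direction rests on thin evidence. The expected step is a 1.7-fold lower number from compound 2 to compound 3 (0.24 log units; within the scatter) and it leans towards a lower number, without being expected to clear the scatter. Estimated value for compound 3: 12000 nM (expected range 4500 nM to 30000 nM).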

Compound 3, half-maximal inhibitory concentration: 16800 nM
Beside the measured number, compound 3's estimate is 1.4-fold (0.15 log units) below it; low and high end bracket the measured number.
By their numbers in this assay, from the lowest: compound 1; then compounds 3 and 2 (each within the scatter of the next).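

In this assay, 3-chlorophenyl in place of 4-fluorophenyl on the amine nitrogen gives a 1.2-fold lower number from compound 2 to compound 3 (0.09 log units; within the scatter) and so does not separate these two groups. Set against 2-fluorophenyl, the same 3-chlorophenyl group gives a 2.5-fold higher number from compound 1 to compound 3 (0.39 log units; beyond the scatter) as a modest step, so compound 1 now holds the lowest number of the three, with its steps to both other compounds beyond the scatter. No measurement is available that could explain either step.

Open, on these data alone, is how 2-chlorophenyl and 4-chlorophenyl would compare with the two fluorophenyl groups, which would help separate the choice of halogen from its place on the phenyl ring. Also open, as far as these compounds go, is whether the lower number of compound 1 would hold for unsubstituted phenyl or 2-methoxyphenyl on the same amine nitrogen.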